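Carbamate Chain Replaces Aryl Group on the Sulfonyl

This account rests on a few compounds, and the source may have more. Where it says the series, first, only, none or still open, it means among the compounds named here.

Compound 1 `CC(C)OC(=O)NCCS(=O)(=O)NC(=O)c1ccc(Nc2nc(NC3(c4ccc(Cl)cc4)CC3)nc(OCC(F)(F)F)n2)cc1`: 100%
Compound 2 `Cc1ccccc1S(=O)(=O)NC(=O)c1ccc(Nc2nc(NC3(c4ccc(Cl)cc4)CC3)nc(OCC(F)(F)F)n2)cc1`: 100%

In an ADME assay on microsomes from liver (Homo sapiens) for metabolic stability, with a stated time of 10 min (a lower number here means that less of the compound is left, a higher number that more of the compound is left), compound 1 gives 100% and compound 2 gives 100%. The step of no change at the digits printed from compound 1 to compound 2 (within the scatter) shows that exchanging the group on the sulfonyl sulfur left the read-out unchanged, so compound 2 stands level with compound 1. Compound 3 `COC(=O)NCCS(=O)(=O)NC(=O)c1ccc(Nc2nc(NC3(c4ccc(Cl)cc4)CC3)nc(OCC(F)(F)F)n2)cc1` differs from compound 2 by 2-((methoxycarbonyl)amino)ethyl in place of 2-methylphenyl on a sulfonyl sulfur. Among the compounds with values here, the only step at this place, no change at the digits printed from compound 1 to compound 2 (within the scatter), lay within the scatter, and compound 3 carries a group closely resembling that of compound 1. For compound 3 the expected step is therefore a number 2 percentage points lower from compound 2 to compound 3 (within the scatter). The estimate for compound 3 is 98%, ranging from 85% to 100%.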

Compound 3, percent of the compound remaining: 90%
Estimate against measurement, compound 3: 8 percentage points above; the measured number falls inside the stated range.
By their numbers in this assay, from the lowest: compounds 3, 1 and 2 (each within the scatter of the next).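

In this assay the exchange of 2-methylphenyl for 2-((methoxycarbonyl)amino)ethyl on the sulfonyl sulfur gives a number 10 percentage points lower from compound 2 to compound 3 (within the scatter) and so a second chain without a ring reads like the aryl group. Shortening the carbamate end, with methyl in place of isopropyl on an oxygen next to a carbonyl group, gives a number 10 percentage points lower from compound 1 to compound 3 (within the scatter) and so this end of the chain can vary too. No measurement here offers an explanation for these readings. The compounds shown leave open whether an amine, a carboxylic acid or a longer chain on the sulfonyl sulfur would read the same.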